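Hydroxamate sulfamides: a methoxyphenyl swap on compound 2

The source may report more compounds than this note shows. Statements on the series, on what has been measured and on what is new or still open speak of the compounds shown alone.

Measured in a functional assay on MONO-MAC-6 cells (Homo sapiens) for inhibition; on this read-out lower numbers stand for stronger inhibition and higher numbers for weaker inhibition:
Compound 1, `C[C@@H](NS(=O)(=O)N1CC=C(c2ccc(Cl)cc2)CC1)C(=O)NO`, gives 1240 nM.
Compound 2, `O=C(NO)[C@H]1CCCCN1S(=O)(=O)N1CC=C(c2ccc(F)cc2)CC1`, gives 300 nM.

Of these two numbers, compound 2 stands lowest, and compound 1 lies beyond the scatter above it. Compound 3, `COc1cccc(C2=CCN(S(=O)(=O)N3CCCC[C@@H]3C(=O)NO)CC2)c1`, differs from compound 2 only by 3-methoxyphenyl in place of 4-fluorophenyl on a double-bonded ring carbon. Going by the values given here, no measured pair shows this change, so its effect is unknown. A step of modest size is expected, in either direction, possibly within the scatter, so compound 3 is estimated at 500 nM (range 150 nM to 1600 nM), a step of a 1.7-fold higher number from compound 2 to compound 3 (0.22 log units; within the scatter).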

Compound 3, half-maximal inhibitory concentration: 260 nM
For compound 3 the middle estimate is 1.9-fold (0.28 log units) above the measured one; low and high end bracket the measured number.
By their numbers in this assay, from the lowest: compounds 3 and 2 (each within the scatter of the next); then compound 1.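

In this assay, the change from 4-fluorophenyl to 3-methoxyphenyl on the double-bonded ring carbon gives a 1.2-fold lower number from compound 2 to compound 3 (0.06 log units; within the scatter), so on the core of compound 2 this position takes an aryl group with one more heavy atom and a hydrogen-bond acceptor without a shift beyond the scatter. Nothing measured here bears on the reason for this result. Still open, on these data alone, is whether an amine or a carboxylic acid on the phenyl ring would read the same, and whether 3-methoxyphenyl would behave alike on the core of compound 1.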